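A Second Methyl on the Branching Carbon of Compound 1

The source may hold more compounds than are shown below. What is called first, only, known or untested is meant among the compounds shown, and "the series" means these compounds.

Among the measured compounds shown here, compound 1 `CC(CCSCCC(N)C(=O)O)CC(=O)O` holds the highest of the two numbers measured so far: in an assay for inhibition of betaine--homocysteine S-methyltransferase 1 (Homo sapiens), tested at 1 uM (on this read-out higher numbers stand for more inhibition at the one concentration tested (going by the name of the read-out) and lower numbers for less inhibition), compound 1 gives 97.8%. Compound 2 `C[N+](C)(CCCSCCC(N)C(=O)O)CC(=O)[O-]` gives 0% in this assay, a gap from compound 1 that lies beyond the usual scatter. The unmeasured compound 3 `CC(C)(CCSCCC(N)C(=O)O)CC(=O)O` differs from compound 1 in one place: methyl in place of hydrogen on a saturated chain carbon bound to three saturated chain carbons. For the measured compounds named here, no step between measured compounds resembles this change, so the expectation rests on compound 1 alone. Compound 3 is expected to keep most of its inhibition, with a step of a number 12.8 percentage points lower from compound 1 to compound 3 (beyond the scatter) that is small, downward if anything, and possibly within the scatter. The estimate for compound 3 is 85%, between 50% and 100%.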

Compound 3, a percentage reported as inhibition, at one concentration (the size of the read-out at that concentration, not a potency): 98.1%
Estimate against measurement, compound 3: 13.1 percentage points below; low and high end bracket the measured number.
By their numbers in this assay, from the lowest: compound 2; then compounds 1 and 3 (each within the scatter of the next).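

Methyl in place of hydrogen on a saturated chain carbon bound to three saturated chain carbons gives a number 0.3 percentage points higher from compound 1 to compound 3 (within the scatter) in this assay and so leaves the inhibition at this one concentration in place. This carbon can therefore carry a second methyl without a loss on this read-out, which compound 1 alone could not show. From the compounds shown here alone, whether an ethyl group or a hydroxyl group on this carbon would keep the inhibition stays open, as does whether compound 1 and compound 3 would still match at a lower concentration. Nothing at hand explains why the number holds.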